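Swapping a phenyl for a 4-fluorobenzyl on the core

The source may report more compounds than this note shows. Statements on the series, on what has been measured and on what is new or still open speak of the compounds shown alone.

Compound 1, `c1ccc(-c2ccc3c(NCCCNCc4ccco4)ccnc3c2)cc1`, was tested in an ADME assay for permeability, using PAMPA, with a stated time of 30 min, at pH 7.4 (on this read-out higher numbers stand for higher permeability and lower numbers for lower permeability), and gives 237 10^-6 cm/s. Its closest measured neighbour is compound 2, `COc1cccc(CNCCCNc2ccnc3cc(-c4ccccc4)ccc23)c1O`, which in this assay gives 237 10^-6 cm/s, so the two sit level at the digits shown, and the step of no change at the digits printed from compound 1 to compound 2 (within the scatter) stays within the usual scatter. That step changes the group on the saturated chain carbon bound to an amine nitrogen, on the far side of the shared core.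

The new compound 3, `Fc1ccc(Cc2ccc3c(NCCCNCc4ccco4)ccnc3c2)cc1`, differs from compound 1 at another place: 4-fluorobenzyl in place of phenyl on an aromatic carbon. No measured pair changes the group at that aromatic carbon, so nothing shown bears directly on this move. Among the measured compounds shown here, the only measured step, from compound 1 to compound 2, shows that a change elsewhere left the read-out unchanged within the scatter. A step of no size beyond the scatter is therefore expected, as a 1.0-fold lower number from compound 1 to compound 3 (0.01 log units; within the scatter). For compound 3 in this assay an estimate of 230 10^-6 cm/s is expected, with a likely range from 120 10^-6 cm/s to 420 10^-6 cm/s.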

Compound 3, apparent permeability: 23 10^-6 cm/s
Beside the measured number, compound 3's estimate is 10-fold (1.00 log units) above it, outside the stated range (below it).
By their numbers in this assay, from the lowest: compound 3; then compounds 1 and 2 (each within the scatter of the next).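

In this assay, the earlier step on the chain, no change at the digits printed from compound 1 to compound 2 (within the scatter), gave no sign of how the read-out would respond to a change on the core, but this aromatic carbon proves sensitive, with 4-fluorobenzyl in place of phenyl giving a 10-fold lower number from compound 1 to compound 3 (1.01 log units; beyond the scatter). This large step comes from a modest change on paper: both groups hold one six-membered aromatic ring of carbon only, neither has a hydrogen-bond donor or acceptor, and neither carries a net charge, while the heavy atoms go from 6 to 8, one of them a fluorine. Nothing available explains why the number falls so far.

The step from compound 1 to compound 3 combines an extra carbon between the ring and the core with a fluorine on the ring, so the compounds shown leave open which of the two goes with the lower number. Placing a plain benzyl or a 4-fluorophenyl at this aromatic carbon would separate the two, and a benzyl on the core of compound 2 would show whether the same step appears with 2-hydroxy-3-methoxyphenyl on the chain.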